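Dimethylamino added to a compound at the assay limit

The compounds below may be only part of what the source reports. "The series", "measured", "known", "first", "only" and "open" are said of these compounds alone.

Measured in an ADME assay on THP-1 cells (Homo sapiens) for cytotoxicity, read by resazurin assay, with a stated time of 48 h; on this read-out higher numbers stand for weaker inhibition and lower numbers for stronger inhibition:
- compound 1 `Cc1ccc(-c2ccc(Cn3cccc(O)c3=O)cc2)cc1`: > 10 ug/mL
- compound 2 `O=c1c(O)cccn1Cc1cn(-c2ccccc2)nn1`: > 10 ug/mL
- compound 3 `Oc1cccn(Cc2cn(-c3ccccc3)nn2)c1=S`: > 10 ug/mL

Compound 3 gives > 10 ug/mL, which is a limit of the assay and not a number. The other two entries are limits as well, so the data show only the limit of > 10 ug/mL in this assay, at which 3 of the 3 values shown sit, and no order among the three.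

Compound 4 `CN(C)c1ccc(-n2cc(Cn3cccc(O)c3=S)nn2)cc1` differs from compound 3 in one place: dimethylamino in place of hydrogen on an aromatic carbon, para to a large group (dimethylamino in place of hydrogen on an aromatic carbon).

Among the measured compounds shown here, no measured step shows what this change does in this assay, so no shift beyond the scatter is expected, and another limit is likely. The expected step is a step that the limit leaves unreadable from compound 3 to compound 4. For compound 4 the estimated value is 15 ug/mL, with an expected range of 6 ug/mL to 40 ug/mL.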

Compound 4, half-maximal inhibitory concentration: > 10 ug/mL
Compound 4: no number, only a limit (the forecaster's own chance of this, stated with the estimate: 70%); the middle value does not contradict the limit.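

In this assay, no step from compound 3 to compound 4 can be read, as both entries are limits and not numbers: the limit of > 10 ug/mL in this assay, at which 4 of the 4 values shown sit.

The compounds shown leave open what dimethylamino in place of hydrogen does to cytotoxicity, and how the four compounds rank against one another.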